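Swapping the Amide Nitrogen for a Hydroxymethyl Group

The source may hold more compounds than are shown below. What is called first, only, known or untested is meant among the compounds shown, and "the series" means these compounds.

Compound 1 `COc1ccc(C(=O)N(O)C(C)c2ccc3oc(-c4ccccc4)cc3c2)cc1OC` gives 200 nM in an assay on RBL cells for inhibition of Polyunsaturated fatty acid 5-lipoxygenase (Rattus norvegicus); a higher number here means a weaker inhibitor, a lower number a stronger inhibitor. Among the compounds with values here, compound 2 `CC(c1ccc2oc(-c3ccccc3)cc2c1)N(O)C(N)=O` gives 410 nM in this assay and stands highest of the two numbers known. Within the data shown here, the only measured step is a 2.1-fold higher number from compound 1 to compound 2 (0.31 log units; beyond the scatter). Compound 3 `CC(c1ccc2oc(-c3ccccc3)cc2c1)N(O)C(=O)CO` differs from compound 2 by hydroxymethyl in place of amino on a carbonyl carbon. Among the measured compounds shown here, no measured step covers this exact change; the one step available concerned a larger exchange on the same carbonyl carbon, and the present change is smaller, so no step beyond the scatter is expected. Compound 3 is therefore estimated at 350 nM, within 150 nM to 800 nM. The expected step is a 1.2-fold lower number from compound 2 to compound 3 (0.07 log units; within the scatter).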

Compound 3, half-maximal inhibitory concentration: 700 nM
Compound 3: middle estimate off by 2.0-fold (0.30 log units), on the low side, within the range that was stated.
By their numbers in this assay, from the lowest: compound 1; then compounds 2 and 3 (each within the scatter of the next).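

On this carbonyl carbon, the exchange of amino for hydroxymethyl gives a 1.7-fold higher number from compound 2 to compound 3 (0.23 log units; within the scatter) in this assay and so does not separate these two small groups. Hydroxymethyl in place of 3,4-dimethoxyphenyl gives a 3.5-fold higher number from compound 1 to compound 3 (0.54 log units; beyond the scatter) and, like amino, leaves compound 1 as the strongest inhibitor of the three. Nothing available explains these differences. As far as these compounds go, it remains open whether a plain phenyl, a methoxymethyl or a dimethylamino group on this carbon would match 3,4-dimethoxyphenyl or the two small groups.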